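The compounds below may be only part of what the source reports. "The series", "measured", "known", "first", "only" and "open" are said of these compounds alone.

Compound 1 `CCn1cc(-c2nc3ccccc3[nH]2)c(=O)c2cc(F)c(N3CCNCC3)nc21` and compound 2 `CCn1cc(-c2nc3ccccc3[nH]2)c(=O)c2cc(F)c(N3CCN(C)CC3)cc21` share much, but the difference between their two cores is not broken down here. In a functional assay on A2780 cells (Homo sapiens) for cytotoxicity, read by MTT assay, with a stated time of 48 h (on this read-out higher numbers stand for weaker inhibition and lower numbers for stronger inhibition), compound 1 gives 4800 nM. Compound 2 gives only a limit of the assay, > 5010000 nM. From the compounds shown here alone, compound 3 `CCn1cc(-c2nc3ccccc3o2)c(=O)c2cc(F)c(N3CCN(C)CC3)cc21` differs from compound 2 by one change, (1,3-benzoxazol-2-yl in place of 1H-benzimidazol-2-yl on an aromatic carbon), and in this assay compound 3 gives 700 nM; the step is an at least 7100-fold lower number from compound 2 to compound 3 (3.85 log units; beyond the scatter), though its true size is unknown because of the limit of > 5010000 nM in this assay, at which 1 of the 3 values shown sits. Compound 4 `CCn1cc(-c2nc3ccccc3o2)c(=O)c2cc(F)c(N3CCNCC3)nc21` arises from compound 1 by the same change, (1,3-benzoxazol-2-yl in place of 1H-benzimidazol-2-yl on an aromatic carbon), at a place described in the same words. A lower number is therefore expected, and the step is estimated as an 8.0-fold lower number from compound 1 to compound 4 (0.90 log units; beyond the scatter), smaller than the other because compound 1 already gives 4800 nM rather than a limit. Compound 4 is expected to give about 600 nM, within 120 nM to 3000 nM.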

Compound 4, half-maximal inhibitory concentration: 15300 nM
Compound 4: the middle estimate sits 26-fold (1.41 log units) below what was measured; the whole stated range lies below it.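

In this assay, putting 1,3-benzoxazol-2-yl in place of 1H-benzimidazol-2-yl gives a 3.2-fold higher number from compound 1 to compound 4 (0.50 log units; beyond the scatter), so the effect of this change does not carry over from one core to the other, not even in its direction: the same change on two cores in this assay, an at least 7100-fold lower number (3.85 log units; beyond the scatter) from compound 2 to compound 3 and a 3.2-fold higher number (0.50 log units; beyond the scatter) from compound 1 to compound 4, at least 22000-fold (4.35 log units) apart, beyond the scatter of two such steps. From the compounds shown here alone, the true size of the earlier step stays unknown, since compound 2 gives only a limit: the limit of > 5010000 nM in this assay, at which 1 of the 4 values shown sits. Which part of the two cores lies behind this reversal is not shown.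

Going by these compounds, it remains open whether a 1,3-benzothiazol-2-yl group, with sulfur in place of the ring oxygen, would shift the number as in compound 3 or as in compound 4. The same question stands for a carboxylic acid at this place on either core.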